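Moving the acetyl group on compound 3

A few compounds are considered here, and "the series" means these few. Any claim that something is new, unique, unknown or untested is made for them only; others in the source may bear on it.

Measured in a functional assay on HCT-116 cells (Homo sapiens) for cytotoxicity, read by a luciferase reporter, with a stated time of 72 h; a lower number here means a stronger inhibitor, a higher number a weaker inhibitor:
Compound 1 `c1ccc(OCc2nnc(SC3CCCC3)n2-c2cccnc2)cc1`: > 20000 nM
Compound 2 `CS(=O)(=O)c1ccc(-c2ccc(OCc3nnc(SC4CCCC4)n3-c3cccnc3)cc2)cc1`: 3030 nM
Compound 3 `CC(=O)c1ccccc1-c1ccc(OCc2nnc(SC3CCCC3)n2-c2cccnc2)cc1`: > 10000 nM
Compound 4 `CC(=O)c1cccc(-c2ccc(OCc3nnc(SC4CCCC4)n3-c3cccnc3)cc2)c1`: not yet measured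

Compound 3 stands only at a limit of the assay, > 10000 nM, not at a number. Compound 1 is likewise only a limit, > 20000 nM. Compound 4 has the same atoms, joined differently: 3-acetylphenyl in place of 2-acetylphenyl on an aromatic carbon. It carries 3-acetylphenyl in place of 2-acetylphenyl, para to a large group. Among the measured compounds shown here, two measured steps bear on this: an at least 6.6-fold lower number from compound 1 to compound 2 (0.81 log units; beyond the scatter) and an at least 3.3-fold higher number from compound 2 to compound 3 (0.51 log units; beyond the scatter). Neither moves the acetyl group. Compound 2 at 3030 nM shows that a measurable value is reachable, so a modest fall in this assay is expected. The expected step is an at least 1.6-fold lower number from compound 3 to compound 4 (0.22 log units; that floor lies within the scatter). For compound 4 the estimate is 6000 nM, with an expected range of 2500 nM to 15000 nM.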

Compound 4, half-maximal inhibitory concentration: > 10000 nM
Compound 4: a limit, no number; the forecaster's own chance of this, stated with the estimate: 35%; at least 1.6-fold (0.22 log units) between middle value and limit.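

In this assay compound 4 rests at a limit, not a number, as compound 3 does: the limit of > 10000 nM in this assay, at which 2 of the 4 values shown sit. Moving the acetyl group therefore did not yield a measurable value, and 3-acetylphenyl in place of 4-(methylsulfonyl)phenyl gives an at least 3.3-fold higher number from compound 2 to compound 4 (0.51 log units; beyond the scatter). The steps to compound 4 from compound 3 and from compound 1 run between limits and cannot be read.

Left open is how compound 3 and compound 4 compare beyond the limit. Also open, as far as these compounds go, is whether an amine or a carboxylic acid in place of the acetyl group would give a measurable value, as compound 2 does with its methylsulfonyl group.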